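Replacing Acetamido with Carboxy on the Sulfonyl Hydrazide

The source may hold more compounds than are shown below. What is called first, only, known or untested is meant among the compounds shown, and "the series" means these compounds.

Among the measured compounds shown here, compound 1 `CC(=O)Nc1ccc(S(=O)(=O)NNc2ccc(Br)cc2)cc1` gives 130 nM in an assay for inhibition of Indoleamine 2,3-dioxygenase 1 (Homo sapiens), read by spectrophotometry, with stated times of 1 h and 4 h (on this read-out lower numbers stand for stronger inhibition and higher numbers for weaker inhibition), the lowest of the two numbers so far, while compound 2 `CC(=O)Nc1ccc(S(=O)(=O)NNc2cccc(Br)c2)cc1` gives 255 nM; the step of a 2.0-fold higher number from compound 1 to compound 2 (0.29 log units; within the scatter) changes only the bromophenyl. Compound 3 `O=C(O)c1ccc(S(=O)(=O)NNc2ccc(Br)cc2)cc1` differs from compound 1 by carboxy in place of acetamido on an aromatic carbon. For the measured compounds named here, no measured step touches this part of the molecule, so the only known step gives no guide to its direction. With nothing to suggest a large shift either way, compound 3 is expected to land near compound 1, with a 1.9-fold higher number from compound 1 to compound 3 (0.28 log units; within the scatter), estimated at 250 nM in a range of 50 nM to 1300 nM.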

Compound 3, half-maximal inhibitory concentration: 61 nM
Compound 3: middle estimate off by 4.1-fold (0.61 log units), on the high side; measured number inside the range.
By their numbers in this assay, from the lowest: compound 3; then compounds 1 and 2 (each within the scatter of the next).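

At this position, on an aromatic carbon para to a large group, acetamido is not needed for a low number in this assay: carboxy in its place gives a 2.1-fold lower number from compound 1 to compound 3 (0.33 log units; beyond the scatter). The entering group has one heavy atom fewer, while the counts of hydrogen-bond donors and acceptors stay the same. Nothing measured here explains the shift.

As far as these compounds go, what an amine or a methyl ester would give at this position remains open. So does whether 3-bromophenyl in place of 4-bromophenyl would give the same step in a compound carrying carboxy.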